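The compounds below may be only part of what the source reports. "The series", "measured", "known", "first", "only" and "open" are said of these compounds alone.

Measured compounds:
compound 1, `Cc1cn(C2CCN(Cc3cccc(Oc4ccccc4)n3)CC2)c(=O)[nH]c1=O`: > 64000 nM
compound 2, `Cc1cccc(Oc2cccc(CN3CCC(n4cc(C)c(=O)[nH]c4=O)CC3)c2)c1`: > 64000 nM

In an ADME assay on MRC5 cells (Homo sapiens) for cytotoxicity, read by fluorescence and resazurin assay, with a stated time of 3 days (on this read-out lower numbers stand for stronger inhibition and higher numbers for weaker inhibition), compound 2 reaches only the limit of the assay, > 64000 nM, not a number. In this assay compound 1 likewise gives only a limit, > 64000 nM. Both measured values share (the limit of > 64000 nM in this assay, at which 2 of the 2 values shown sit). Compound 3, `Cc1cn(C2CCN(Cc3cccc(Oc4cccc(C(F)(F)F)c4)c3)CC2)c(=O)[nH]c1=O`, differs from compound 2 by trifluoromethyl in place of methyl on an aromatic carbon. For the measured compounds named here, no measured pair shows the size of such a step, so the expected change is none beyond the usual scatter, with a step that the limit leaves unreadable from compound 2 to compound 3 as the estimated step. For compound 3 the expected value in this assay is 80000 nM, with a range from 30000 nM to 200000 nM, and most likely once more only a limit is reported.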

Compound 3, half-maximal inhibitory concentration: 12400 nM
Estimate against measurement, compound 3: 6.5-fold (0.81 log units) above; the measured number lies below the stated range.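

In this assay, trifluoromethyl in place of methyl on the outer aromatic ring gives an at least 5.1-fold lower number from compound 2 to compound 3 (0.71 log units; beyond the scatter). This shows that a change at this one place is enough to bring cell toxicity into measurable range, so this position is not indifferent to what sits on it. The true size of the step stays unknown, since compound 1 and compound 2 give no number, only a limit: the limit of > 64000 nM in this assay, at which 2 of the 3 values shown sit.

The compounds shown leave open whether other groups at this place, such as chlorine, a nitrile or an amine, would do the same. As far as these compounds go, whether trifluoromethyl has this effect on the core of compound 1 also remains open.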